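The source may hold more compounds than are shown below. What is called first, only, known or untested is meant among the compounds shown, and "the series" means these compounds.

Of the compounds shown here, three sharing one core have been measured so far. Compound 1 `O=C1Nc2ccc(S(=O)(=O)N3CCOCC3)cc2/C1=N/NC(=O)c1ccccc1` gives 18100 nM in a functional assay on HepG2 cells (Homo sapiens) for cytotoxicity, read by sulforhodamine B assay, with a stated time of 24 h; on this read-out higher numbers stand for weaker inhibition and lower numbers for stronger inhibition. Compound 2 `N#CCC(=O)N/N=C1\C(=O)Nc2ccc(S(=O)(=O)N3CCOCC3)cc21` gives 7530 nM, and compound 3 `CC(=O)c1cccc(/N=C2\C(=O)Nc3ccc(S(=O)(=O)N4CCOCC4)cc32)c1` gives 28600 nM. Compound 3 thus shows the highest of the three numbers, although the gap to compound 1 lies within the scatter, so the two cannot be ordered; only compound 2 stands clearly apart from it, as seen in a 3.8-fold higher number from compound 2 to compound 3 (0.58 log units; beyond the scatter).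

The next step leads to compound 4 `CC(=O)N/N=C1\C(=O)Nc2ccc(S(=O)(=O)N3CCOCC3)cc21`. Its structure differs from compound 3 in one place: acetamido in place of 3-acetylphenyl on a double-bonded nitrogen. Two of the measured steps bear on this change, since both replace a hydrazide on the double-bonded nitrogen with the 3-acetylphenyl group. From compound 1 to compound 3 the number moved by a 1.6-fold higher number from compound 1 to compound 3 (0.20 log units; within the scatter), and from compound 2 to compound 3 by a 3.8-fold higher number from compound 2 to compound 3 (0.58 log units; beyond the scatter). Compound 4 runs the opposite way, back toward a hydrazide, here acetamido, so a modest fall in the number is expected in this assay, between those two sizes.

For compound 4 the expected step is therefore a 2.6-fold lower number from compound 3 to compound 4 (0.41 log units; beyond the scatter), and the value is estimated at 11000 nM, with a range from 4500 nM to 30000 nM.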

Compound 4, half-maximal inhibitory concentration: 27500 nM
The estimate for compound 4 lay 2.5-fold (0.40 log units) below the measured number; the range from low to high includes it.
By their numbers in this assay, from the lowest: compound 2; then compounds 1, 4 and 3 (each within the scatter of the next).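

The result shows that a hydrazide on the double-bonded nitrogen does not by itself lower the number in this assay: acetamido in place of 3-acetylphenyl gives a 1.0-fold lower number from compound 3 to compound 4 (0.02 log units; within the scatter) and so leaves the two compounds inseparable, even though the ring and its acetyl group are gone. Among the hydrazides, the change at the carbonyl carbon matters only in one case, since methyl in place of phenyl gives a 1.5-fold higher number from compound 1 to compound 4 (0.18 log units; within the scatter) and does not separate the pair, whereas hydrogen in place of cyano on the saturated chain carbon gives a 3.7-fold higher number from compound 2 to compound 4 (0.56 log units; beyond the scatter) and does. Compound 2, the only one carrying a nitrile, therefore stands apart from the other three compounds, and nothing shown here explains this difference.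

From the compounds shown here alone, it remains open whether the nitrile must stay on that chain carbon or whether a longer chain ending in a nitrile would hold the lower number. Equally open, going by these compounds, is whether a carboxylic acid or an amine in place of the cyano group would do the same.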